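The source may report more compounds than this note shows. Statements on the series, on what has been measured and on what is new or still open speak of the compounds shown alone.

Among the compounds with values here, compound 2 `COc1ccc(CNC(=O)/C(C#N)=C/c2cccc3ccccc23)cc1` gives 16000 nM in a functional assay on MCF7 cells (Homo sapiens) for inhibition, read by MTT assay, with a stated time of 72 h (on this read-out lower numbers stand for stronger inhibition of growth and higher numbers for weaker inhibition of growth), the higher of the two numbers measured so far. Compound 1 `N#C/C(=C\c1ccc[nH]1)C(=O)NCc1ccc(Cl)c(Cl)c1` gives 6000 nM in this assay, and the gap between the two lies beyond the scatter. Compound 3 `N#C/C(=C\c1cccc2ccccc12)C(=O)NCc1ccc(Cl)c(Cl)c1` follows from compound 2 by 3,4-dichlorophenyl in place of 4-methoxyphenyl on a saturated chain carbon bound to an amide-type nitrogen. A moderate step toward a lower number is expected in this assay because compound 1, which carries the same 3,4-dichlorophenyl, gives 6000 nM. Compound 3 is expected to give 7000 nM, with a range of 2500 nM to 20000 nM. The estimated step is a 2.3-fold lower number from compound 2 to compound 3 (0.36 log units; beyond the scatter).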

Compound 3, concentration for 50% growth inhibition: 8000 nM
Beside the measured number, compound 3's estimate is 1.1-fold (0.06 log units) below it, within the range that was stated.
By their numbers in this assay, from the lowest: compounds 1, 3 and 2 (each within the scatter of the next, the first and the last beyond it).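

The exchange of 4-methoxyphenyl for 3,4-dichlorophenyl on a saturated chain carbon bound to an amide-type nitrogen gives the series its first comparison at a single place: a 2.0-fold lower number from compound 2 to compound 3 (0.30 log units; within the scatter) in this assay. At this position, the two groups cannot be told apart in this read-out, even though the hydrogen-bond acceptor of 4-methoxyphenyl leaves with the change. Nothing available explains this result.

Still open, going by these compounds, is whether a carboxylic acid or an amine at this position would read apart from these two aryl groups.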